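Hydroxy in place of methyl: notes on the series

A few compounds are considered here, and "the series" means these few. Any claim that something is new, unique, unknown or untested is made for them only; others in the source may bear on it.

Of the compounds shown here, two sharing one core have measured values so far in a functional assay, read by spectrophotometry, with a stated time of 20 min; on this read-out higher numbers stand for weaker inhibition and lower numbers for stronger inhibition. Compound 1 (`Cc1ccccc1-c1oc2ccccc2c(=O)c1C`) gives 156 ug/mL, and compound 2 (`Cc1cccc(-c2oc3ccccc3c(=O)c2C)c1`) gives 250 ug/mL. These two values lie within the scatter of each other, so compound 1 stands level with compound 2 on the numbers available.

Compound 3 (`Cc1c(-c2ccccc2O)oc2ccccc2c1=O`) has not yet been measured. Its difference from compound 1 is hydroxy in place of methyl on an aromatic carbon of a six-membered aromatic ring of carbon only, ortho to a large group.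

For the measured compounds named here, no measured pair differs in one place only, so the data offer no direct guide to the size of this step. A small shift towards stronger inhibition is expected in this assay, not clearly beyond the scatter, and this direction remains a judgement. The estimated step is a 1.7-fold lower number from compound 1 to compound 3 (0.24 log units; within the scatter). Compound 3 is expected at 90 ug/mL, with an estimated range of 30 ug/mL to 250 ug/mL.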

Compound 3, half-maximal inhibitory concentration: 79.4 ug/mL
Beside the measured number, compound 3's estimate is 1.1-fold (0.05 log units) above it, and the stated range covers the measured number.
By their numbers in this assay, from the lowest: compounds 3, 1 and 2 (each within the scatter of the next, the first and the last beyond it).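

In this assay, for the compounds shown here, hydroxy in place of methyl on an aromatic carbon, ortho to a large group, gives a 2.0-fold lower number from compound 1 to compound 3 (0.29 log units; within the scatter), and this is the first step between compounds that differ in one place only. Going by these compounds alone, it gives a first size for this change at this position: the exchange brings in a hydrogen-bond donor and a hydrogen-bond acceptor, yet the values of the two compounds stay within the scatter of each other, so a single pair shows no clear separation and the direction of the step is not established. Nothing measured on these compounds bears on what lies behind this step.

On these data alone, whether an amine or a methoxy group on the same aromatic carbon would give a step beyond the scatter remains open. Also open, as far as these compounds go, is whether hydroxy in place of the methyl on the aromatic ring of compound 2 would give a step of similar size, or whether this result holds only for the place seen in compound 1.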